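The source may hold more compounds than are shown below. What is called first, only, known or untested is meant among the compounds shown, and "the series" means these compounds.

compound 1 `CC/C=C\C[C@H]1C(=O)C=C[C@H]1CC(=O)Oc1ccccc1` gives 158 uM
compound 2 `CC/C=C\C[C@H]1C(=O)C=C[C@H]1CC(=O)Oc1ccccc1OC` gives 161 uM
compound 3 `CC/C=C\C[C@H]1C(=O)C=C[C@H]1CC(=O)OCCOCCOCCO` gives 162 uM

In an ADME assay on RAW264.7 cells (Mus musculus) for cytotoxicity, read by MTT assay, with a stated time of 24 h (on this read-out higher numbers stand for lower toxicity in this test and lower numbers for higher toxicity in this test), compound 1 at 158 uM stands within the scatter of both compound 2 and compound 3. Compound 4 (`CC/C=C\C[C@H]1C(=O)C=C[C@H]1CC(=O)OC(C)C`) departs from compound 1 by one change (isopropyl in place of phenyl on an oxygen next to a carbonyl group), isopropyl in place of phenyl on an oxygen next to a carbonyl group. Among the measured compounds shown here, the only measured step, methoxy in place of hydrogen on an aromatic carbon, gave a 1.0-fold higher number from compound 1 to compound 2 (0.01 log units; within the scatter) and bears on this change only indirectly. Compound 3, with another group on that oxygen, gives 162 uM and so stays level with compound 1. No shift beyond the scatter is therefore expected in this assay for this change. An expected step of a 1.1-fold lower number from compound 1 to compound 4 (0.02 log units; within the scatter) would stay within the scatter. For compound 4 the estimated value is 150 uM with an expected range from 80 uM to 280 uM in this test.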

Compound 4, half-maximal toxic concentration: 58 uM
Estimate against measurement, compound 4: 2.6-fold (0.41 log units) above; the whole stated range lies above it.
By their numbers in this assay, from the lowest: compound 4; then compounds 1, 2 and 3 (each within the scatter of the next).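

In this assay, isopropyl in place of phenyl on an oxygen next to a carbonyl group gives a 2.7-fold lower number from compound 1 to compound 4 (0.44 log units; beyond the scatter) and so shows that this position can move the number beyond the scatter, which the level values of compounds 1, 2 and 3 had not shown. The three earlier groups on that oxygen stand together, and compound 4 alone stands apart from them. Nothing at hand explains the shift.

Going by these compounds, whether an amine, a carboxylic acid or a longer alkyl chain on that oxygen would stay level with compound 1 or fall with compound 4 remains open.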